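Moving the carboxy group in compound 3

The source may hold more compounds than are shown below. What is called first, only, known or untested is meant among the compounds shown, and "the series" means these compounds.

In an ADME assay on MDCKII-LE cells (Canis lupus familiaris) for permeability (a higher number here means that the compound crosses the layer faster, a lower number that the compound crosses the layer more slowly), compound 1 `Cc1ccc(NC(=O)[C@H](CC2CCCC2)n2cnc(C(F)(F)F)c2)nc1` gives 17.4 10^-6 cm/s and compound 2 `O=C(O)c1ccc(NC(=O)[C@H](CC2CCCC2)n2cnc(C(F)(F)F)c2)nc1` gives 1 10^-6 cm/s as the lower of the two numbers. Going by the values given here, compound 3 `O=C(O)c1cccc(NC(=O)[C@H](CC2CCCC2)n2cnc(C(F)(F)F)c2)n1` has 6-carboxypyridin-2-yl in place of 5-carboxypyridin-2-yl on an amide-type nitrogen as its only change. Among the compounds with values here, the one measured step (a 17-fold lower number from compound 1 to compound 2 (1.24 log units; beyond the scatter)) is large and puts carboxy in place of methyl on an aromatic carbon. Compound 2 and compound 3 both carry carboxy and that step does not move it, so no step beyond the scatter is expected (a 1.5-fold higher number from compound 2 to compound 3 (0.18 log units; within the scatter)). Compound 3 is estimated at 1.5 10^-6 cm/s (range 0.5 10^-6 cm/s to 4.5 10^-6 cm/s).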

Compound 3, apparent permeability: 0.7 10^-6 cm/s
For compound 3 the middle estimate is 2.1-fold (0.33 log units) above the measured one; measured number inside the range.
By their numbers in this assay, from the lowest: compounds 3 and 2 (each within the scatter of the next); then compound 1.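

In this assay the two carboxy placements cannot be told apart: 6-carboxypyridin-2-yl in place of 5-carboxypyridin-2-yl gives a 1.4-fold lower number from compound 2 to compound 3 (0.15 log units; within the scatter) and so stays within the scatter. The large step away from the methyl compound appears with this placement too, as a 25-fold lower number from compound 1 to compound 3 (1.40 log units; beyond the scatter) shows, so it is not tied to one carboxy placement. Nothing available explains these numbers. Going by these compounds, what an amine or a hydroxy group at this place would give in this assay remains open, as does a carboxylic acid on a longer chain.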